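Pyridyl for fluorophenyl on the pyrrolidine in a TRPM8 series

This account rests on a few compounds, and the source may have more. Where it says the series, first, only, none or still open, it means among the compounds named here.

For the measured compounds named here, compound 3 `O=C(C(Nc1ccccc1F)c1ccc(C(F)(F)F)cc1)N1CCCC1c1ccccc1F` gives 7 nM in an assay on HEK293 cells for antagonist activity at transient receptor potential M8 protein (Canis lupus familiaris), read by fluorescence and calcium flux, with a stated time of 5 min (a lower number here means a stronger inhibitor, a higher number a weaker inhibitor), the lowest of the three numbers measured so far. Compound 1 `O=C(C(Nc1ccccc1)c1ccc(C(F)(F)F)cc1)N1CCCC1c1ccccc1F` gives 30 nM and compound 2 `COc1ccccc1C1CCCN1C(=O)C(Nc1ccccc1)c1ccc(C(F)(F)F)cc1` gives 33 nM in this assay. The step of a 4.3-fold lower number from compound 1 to compound 3 (0.63 log units; beyond the scatter) concerns the aniline ring; the step of a 1.1-fold higher number from compound 1 to compound 2 (0.04 log units; within the scatter) concerns the aryl group on the five-membered ring and shows that at least one change there stays within the scatter. Compound 4 `O=C(C(Nc1ccccc1F)c1ccc(C(F)(F)F)cc1)N1CCCC1c1ccccn1` differs from compound 3 by pyridin-2-yl in place of 2-fluorophenyl on a saturated ring carbon. Going by the values given here, no measured step covers this change; the compound 1 to compound 2 result is the only guide and is weak. A modestly higher number, a 2.9-fold higher number from compound 3 to compound 4 (0.46 log units; beyond the scatter), is expected in this assay. Compound 4 is estimated at 20 nM, within 6 nM to 70 nM.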

Compound 4, half-maximal inhibitory concentration: 25 nM
Estimate against measurement, compound 4: 1.3-fold (0.10 log units) below, within the range that was stated.
By their numbers in this assay, from the lowest: compound 3; then compounds 4, 1 and 2 (each within the scatter of the next).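

For the compounds shown here, the aryl group on this saturated ring carbon does respond to change in this assay: pyridin-2-yl in place of 2-fluorophenyl gives a 3.6-fold higher number from compound 3 to compound 4 (0.55 log units; beyond the scatter), whereas the only earlier step here, a 1.1-fold higher number from compound 1 to compound 2 (0.04 log units; within the scatter), stayed within the scatter. The change removes the fluorine and brings in a ring nitrogen with one hydrogen-bond acceptor, and this single step cannot separate the two. No data at hand bear on why the step arises.

Open, going by these compounds, is how unsubstituted phenyl or pyridin-3-yl would read on this carbon. Also open, on these data alone, is whether the fluoro gain on the aniline ring holds with pyridin-2-yl present.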